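Replacing cyclopentyl with 4-isopropylbenzyl on the shared core

A few compounds are considered here, and "the series" means these few. Any claim that something is new, unique, unknown or untested is made for them only; others in the source may bear on it.

Of the compounds shown here, three built on one shared core have been measured. Compound 1 `Cc1nn(-c2ncnc3nc[nH]c23)c2c1C(OCc1ccc(Cl)cc1Cl)CC(=O)N2` gives 243 nM in a functional assay on HEK293 cells for agonist activity at G-protein coupled receptor 39 (Homo sapiens), read by scintillation proximity assay and inositol phosphate accumulation, with a stated time of 75 min; a higher number here means that more compound is needed for the effect, a lower number that less compound is needed. Compound 2 `Cc1nn(-c2ncnc3nc[nH]c23)c2c1C(OC1CCCC1)CC(=O)N2` gives 62 nM in this assay, the lowest of the three numbers in hand. For the measured compounds named here, compound 3 `Cc1nn(-c2ncnc3nc[nH]c23)c2c1C(C(=O)NCc1ccc(F)cc1)CC(=O)N2` gives 1220 nM in this assay, the highest of the three; it shares no single-change step with compound 2, so its value stands only as a distant point of comparison.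

Going by the values given here, the one step that changes a single place is a 3.9-fold lower number from compound 1 to compound 2 (0.59 log units; beyond the scatter), a modest move in favour of the cyclopentyl. Compound 4 `Cc1nn(-c2ncnc3nc[nH]c23)c2c1C(OCc1ccc(C(C)C)cc1)CC(=O)N2` differs from compound 2 by 4-isopropylbenzyl in place of cyclopentyl on an oxygen on a saturated carbon. This change runs in the opposite sense to the measured step, returning a benzyl group to the oxygen. Because a 3.9-fold lower number from compound 1 to compound 2 (0.59 log units; beyond the scatter) was modest, the number for compound 4 in this assay is expected to rise by a comparable, modest amount, about a 2.9-fold higher number from compound 2 to compound 4 (0.46 log units; beyond the scatter). Compound 4 is therefore estimated at 180 nM, with a likely range from 60 nM to 600 nM.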

Compound 4, half-maximal effective concentration: 1690 nM
Beside the measured number, compound 4's estimate is 9.4-fold (0.97 log units) below it; the whole stated range lies below it.
By their numbers in this assay, from the lowest: compound 2; then compound 1; then compounds 3 and 4 (each within the scatter of the next).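

For the compounds shown here, at this oxygen on a saturated carbon, the position proves far more sensitive than the earlier compounds suggested: in this assay the change to 4-isopropylbenzyl gives a 27-fold higher number from compound 2 to compound 4 (1.44 log units; beyond the scatter), a large step with a group of 10 heavy atoms entering for one of 5. The two benzyl groups are also not interchangeable, since 4-isopropylphenyl in place of 2,4-dichlorophenyl gives a 7.0-fold higher number from compound 1 to compound 4 (0.84 log units; beyond the scatter), so the substituents on the aromatic ring alter the result as well as the choice of group on the oxygen. Nothing available explains either step.

Going by these compounds, it remains open where an unsubstituted benzyl or a cyclohexyl on this oxygen would fall relative to compound 2 and compound 4. Also open, on these data alone, is how a smaller chain such as ethyl, or a group carrying an amine, would fare here.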